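Fluorophenyl positional swap in the proline carboxamide series

The source may hold more compounds than are shown below. What is called first, only, known or untested is meant among the compounds shown, and "the series" means these compounds.

Compound 1 `NC(=O)[C@@H]1CC[C@H](c2ccc(OCc3ccc(F)cc3)cc2)N1` is the starting point for this step. In an ADME assay on brain (Rattus norvegicus) for protein binding (on this read-out lower numbers stand for a smaller free fraction and higher numbers for a larger free fraction), compound 1 has "not determined" (no result reported) recorded, so its standing in this read-out cannot be stated. Within the data shown here, the only number available across the series comes from compound 2 `N#Cc1ccccc1Oc1ccc([C@H]2CC[C@@H](C(N)=O)N2)cc1`, which in this assay gives 0.076. Compound 3 `N#Cc1cc([C@H]2CC[C@@H](C(N)=O)N2)ccc1OCc1ccccc1F` likewise carries "not determined" (no result reported) in this assay. The shared core is unchanged across the step followed here.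

Compound 4 `NC(=O)[C@@H]1CC[C@H](c2ccc(OCc3cccc(F)c3)cc2)N1` differs from compound 1 in one place: 3-fluorophenyl in place of 4-fluorophenyl on a saturated chain carbon bound to an oxygen on an aromatic ring. The same atoms are present in both, joined differently.

Among the measured compounds shown here, no measured pair in this set shows what such a change does to this assay. With both compound 1 and compound 3 without a number, there is nothing to set compound 4 against other than compound 2, which carries a different substitution pattern altogether. The expectation for the step from compound 1 to compound 4 is therefore a difference that stays within the usual scatter, in no particular direction. Compound 4 is estimated at 0.035 in this assay, with a range from 0.012 to 0.09.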

Compound 4, unbound fraction: 0.01
Estimate against measurement, compound 4: 3.5-fold (0.54 log units) above, and the stated range ends above it.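

In this assay, among these compounds, compound 4 gives 0.01 but compound 1 has no single number, so no step between compound 1 and compound 4 can be read. No supporting data bear on this result. The compounds shown leave open what replacing 4-fluorophenyl with 3-fluorophenyl does in this assay.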